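Dihydropyrimidinone series: second ring-nitrogen acylation, calcium channel inhibition

The source may hold more compounds than are shown below. What is called first, only, known or untested is meant among the compounds shown, and "the series" means these compounds.

Measured so far:
compound 1 `CC1=C(C(=O)OC(C)C)C(c2cccc([N+](=O)[O-])c2)NC(=O)N1`: 46600 nM
compound 2 `COC(=O)N1C(=O)NC(C)=C(C(=O)OC(C)C)C1c1cccc([N+](=O)[O-])c1`: 2960 nM
compound 3 `CC1=C(C(=O)OC(C)C)C(c2cccc([N+](=O)[O-])c2)N(C(=O)OC(C)C)C(=O)N1`: 660 nM

All three were tested in an assay on HEK293 cells for antagonist activity at Voltage-dependent L-type calcium channel subunit alpha-1D (Rattus norvegicus), read by FLIPR; on this read-out higher numbers stand for weaker inhibition and lower numbers for stronger inhibition. Compound 2 stands second highest of the three numbers; its nearest neighbour is compound 3, the step being a 4.5-fold lower number from compound 2 to compound 3 (0.65 log units; beyond the scatter), and its furthest is compound 1, the step being a 16-fold lower number from compound 1 to compound 2 (1.20 log units; beyond the scatter). Compound 4 `COC(=O)N1C(=O)N(C(=O)OC)C(c2cccc([N+](=O)[O-])c2)C(C(=O)OC(C)C)=C1C` is not yet measured. It differs from compound 2 by methoxycarbonyl in place of hydrogen on an amide-type nitrogen in a ring, so that both amide-type ring nitrogens now carry a carbamate.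

The measured steps that bear on acylation of a ring nitrogen are a 16-fold lower number from compound 1 to compound 2 (1.20 log units; beyond the scatter) and a 71-fold lower number from compound 1 to compound 3 (1.85 log units; beyond the scatter), both large. Among the compounds with values here, those steps, however, concern the other ring nitrogen, the one carrying the group in compound 2; no measured pair shows what acylation of the nitrogen next to the ring atom that bears a methyl group does. A second acyl group is therefore expected to give at most a modest lowering in this assay, with a real chance of no step beyond the scatter. For compound 4 the estimate is 1500 nM, within 350 nM to 6000 nM, which means an expected step of a 2.0-fold lower number from compound 2 to compound 4 (0.30 log units; within the scatter).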

Compound 4, half-maximal inhibitory concentration: 5880 nM
Compound 4: middle estimate off by 3.9-fold (0.59 log units), on the low side, within the range that was stated.
By their numbers in this assay, from the lowest: compound 3; then compounds 2 and 4 (each within the scatter of the next); then compound 1.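

In this assay, within the data shown here, methoxycarbonyl in place of hydrogen on the amide-type nitrogen next to the ring atom that bears a methyl group gives a 2.0-fold higher number from compound 2 to compound 4 (0.30 log units; within the scatter) and so shows no step beyond the scatter at this position, which the earlier compounds left unread. Among these compounds, the large step for the same group on the other amide-type ring nitrogen, a 16-fold lower number from compound 1 to compound 2 (1.20 log units; beyond the scatter) in the same assay, therefore has no counterpart here when compound 2 is the starting point. Nothing available accounts for this difference between the two nitrogens.

Still open, going by these compounds, is how methoxycarbonyl on this nitrogen reads when the other ring nitrogen keeps its hydrogen. Also open, on these data alone, is whether isopropoxycarbonyl, acetyl or a longer chain ending in an amine at this position would stay within the scatter of compound 2.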